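Swapping the Amide Group of Compound 3

The source may hold more compounds than are shown below. What is called first, only, known or untested is meant among the compounds shown, and "the series" means these compounds.

In an ADME assay (Rattus norvegicus, strain Han-wistar) for pharmacokinetics, at a dose of 1.5 umol/kg by the intravenous route (on this read-out lower numbers stand for slow clearance and higher numbers for fast clearance), compound 3 `CC(C)n1cc(-c2ccnc3[nH]c(C4CCN(CC(=O)N5CCCCC5)CC4)cc23)ccc1=O` gives 159 mL/min/kg and sits at the top of the measured numbers. Compound 1 `CC(C)n1cc(-c2ccnc3[nH]c(C4CCN(CC(=O)N5CCCC5)CC4)cc23)ccc1=O` gives 91 mL/min/kg and lies within the scatter of compound 3. Compound 2 `CC(C)n1nc(-c2ccnc3[nH]c(C4CCN(CC(=O)N(C)C)CC4)cc23)ccc1=O` gives 72 mL/min/kg and lies lower than compound 3, just beyond the scatter.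

The unmeasured compound 4 `CC(C)n1cc(-c2ccnc3[nH]c(C4CCN(CC(=O)N(C)C)CC4)cc23)ccc1=O` has dimethylamino in place of piperidin-1-yl on a carbonyl carbon and so loses the ring of that amide. Among the compounds with values here, one measured step touches the same place: a 1.7-fold higher number from compound 1 to compound 3 (0.24 log units; within the scatter) came with piperidin-1-yl in place of pyrrolidin-1-yl on a carbonyl carbon. That step stayed inside the scatter, so on its own it is only a weak guide. Compound 2 also carries dimethylamino on a carbonyl carbon, and its value of 72 mL/min/kg is the closest reference, although its core is not the same.

Together these point to a lower number in this assay for the new amide, by an amount near the edge of the scatter. The expected step is a 2.0-fold lower number from compound 3 to compound 4 (0.30 log units; within the scatter) and it rests on very few data. Compound 4 is estimated at 80 mL/min/kg with 45 mL/min/kg to 135 mL/min/kg as the expected range.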

Compound 4, clearance: 77 mL/min/kg
Estimate against measurement, compound 4: 1.0-fold (0.02 log units) above; the range from low to high includes it.
By their numbers in this assay, from the lowest: compounds 2, 4, 1 and 3 (each within the scatter of the next, the first and the last beyond it).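

In this assay, within the data shown here, dimethylamino in place of piperidin-1-yl on a carbonyl carbon gives a 2.1-fold lower number from compound 3 to compound 4 (0.31 log units; beyond the scatter), which makes this the first change at this position on the shared core to clear the scatter, though only modestly. The effect does not extend to every amide shown, since the swap from pyrrolidin-1-yl to dimethylamino gives a 1.2-fold lower number from compound 1 to compound 4 (0.07 log units; within the scatter), and the change of the aromatic group on an aromatic carbon, with the amide held constant, gives a 1.1-fold higher number from compound 2 to compound 4 (0.03 log units; within the scatter), so compound 4 cannot be told apart from either neighbour. Nothing in the available data explains why piperidin-1-yl stands apart from dimethylamino but not from pyrrolidin-1-yl.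

The compounds shown cover only three amine parts on this carbonyl carbon, all of them fully substituted on the amide nitrogen, so it remains open how a morpholin-4-yl group, with an oxygen in its ring, or a plain unsubstituted amide would read out in this measurement. From the compounds shown here alone, it is also open whether the step from piperidin-1-yl to dimethylamino would be of similar size on the core of compound 2.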